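Aryl swap on the shared core: compound 2 to compound 4

The source may report more compounds than this note shows. Statements on the series, on what has been measured and on what is new or still open speak of the compounds shown alone.

Measured so far in an ADME assay on microsomes from liver (Rattus norvegicus) for metabolic stability, read by LC-MS, using NADPH, at 37 degrees C; a lower number here means that the compound disappears faster, a higher number that the compound lasts longer:
- compound 1 `Cc1ccccc1-c1nc(CN2CCC(C(=O)NCCCN3CC(C)(C)CC(C)(C)C3)CC2)c(C)o1` gives 0.095 h
- compound 2 `Cc1oc(-c2c(Cl)cccc2Br)nc1CN1CCC(C(=O)NCCCN2C[C@H](C)C[C@H](C)C2)CC1` gives 0.0233 h
- compound 3 `Cc1cccc(Cl)c1-c1nc(CN2CCC(C(=O)NCCCN3CCC(C)(C)CC3)CC2)c(C)o1` gives 0.0733 h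

All three compounds disappear quickly. Compound 2 stands lowest of the three in this assay; its gap to compound 3 and its larger gap to compound 1 both lie beyond the usual scatter, so compound 2 is the least stable of the measured set.

Compound 4 `Cc1cc(C)cc(-c2nc(CN3CCC(C(=O)NCCCN4C[C@H](C)C[C@H](C)C4)CC3)c(C)o2)c1` is not yet measured. It differs from compound 2 in one place: 3,5-dimethylphenyl in place of 2-bromo-6-chlorophenyl on an aromatic carbon. The rest of the molecule, including the piperidine bearing two methyl groups on the amide side chain, is unchanged. Among the compounds with values here, no pair of measured compounds isolates this same swap, so the step has to be judged from the spread of the three numbers alone.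

The expectation for compound 4 is a modest rise, a 1.7-fold higher number from compound 2 to compound 4 (0.23 log units; within the scatter), at the edge of the scatter. Compound 4 is estimated at 0.04 h, with a range from 0.015 h to 0.11 h.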

Compound 4, half-life: < 0.5 h
Compound 4: no number, only a limit; the forecaster's own chance of this, stated with the estimate: 5%; the middle value lies beyond the limit too.
By their numbers in this assay, from the lowest: compound 2; then compounds 3 and 1 (each within the scatter of the next).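

In this assay compound 4 gives < 0.5 h, a limit and not a number; the step from compound 2 to compound 4 cannot be read. The compounds shown leave open how 3,5-dimethylphenyl in place of 2-bromo-6-chlorophenyl on the shared core shifts the half-life.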